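This account rests on a few compounds, and the source may have more. Where it says the series, first, only, none or still open, it means among the compounds named here.

Three compounds have so far been measured in a functional assay on Right cardiac atrium for agonist activity at histamine H2 receptor (Cavia porcellus), with a stated time of 30 min, in the presence of a further agent that is not named here; on this read-out higher numbers stand for an effect only at larger amounts of compound and lower numbers for an effect already at smaller amounts:

Compound 1, `Cc1nc(N)sc1CCCN/C(N)=N/C(=S)NC(c1ccccc1)c1ccccc1`: 66.1 nM
Compound 2, `Cc1nc(N)sc1CCCN/C(N)=N/C(=O)NC(C)c1cccc(F)c1`: 26.3 nM
Compound 3, `CCCCCNC(=O)/N=C(\N)NCCCc1sc(N)nc1C`: 5.75 nM

Among these three numbers compound 2 stands second highest. Compound 1 gives a higher number than compound 2, and that gap lies beyond the usual scatter of this assay. Compound 3 gives the lowest number of the three, and its gap to compound 2 also lies beyond the scatter, so compound 3 is the one of the three that acts at the smallest amounts.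

The account now turns from compound 2 to compound 4, `Cc1nc(N)sc1CCCN/C(N)=N/C(=O)NC(C)c1ccc(Br)cc1`, which has not yet been measured. The two structures differ in one place: 4-bromophenyl in place of 3-fluorophenyl on a saturated chain carbon bound to an amide-type nitrogen and a saturated chain carbon. Among the compounds with values here, none of the measured compounds differ from one another in a single place, so no measured step shows what a change of this kind does in this assay. The remaining parts of compound 2 are carried over unchanged into compound 4.

Within the data shown here, with no measured step to guide it, the expected step of a 1.1-fold higher number from compound 2 to compound 4 (0.06 log units; within the scatter) is estimated not to exceed the scatter in either direction. Compound 4 is therefore expected to give about 30 nM, with a range from 10 nM to 90 nM.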

Compound 4, half-maximal effective concentration: 55 nM
For compound 4 the middle estimate is 1.8-fold (0.26 log units) below the measured one; the range from low to high includes it.
By their numbers in this assay, from the lowest: compound 3; then compound 2; then compounds 4 and 1 (each within the scatter of the next).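

In this assay, within the data shown here, the change to 4-bromophenyl on this saturated chain carbon gives a 2.1-fold higher number from compound 2 to compound 4 (0.32 log units; beyond the scatter), the first measured single-place step, and so the first sign that the aryl group at this position can shift the read-out. The step is modest, yet it arises between two groups that match in heavy-atom count and in having one six-membered aromatic ring of carbon only, with neither carrying a hydrogen-bond donor or acceptor, so those counted features alone do not distinguish compound 2 from compound 4. Nothing available bears on why the number moves with this exchange.

The exchange alters both the halogen and its numbered ring position, so this single step cannot assign the shift to either change alone; 3-bromophenyl or 4-fluorophenyl on the same carbon would separate the two. Unsubstituted phenyl at this position also remains open, leaving it unknown how either halogen-bearing group compares with a ring that carries no halogen.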